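Moving the nitrophenyl attachment on a shared core

The source may report more compounds than this note shows. Statements on the series, on what has been measured and on what is new or still open speak of the compounds shown alone.

Compound 1 `COc1cc(C(=O)c2cn(-c3ccccc3)cc2-c2ccccc2[N+](=O)[O-])cc(OC)c1OC` gives 49 nM in a functional assay on MCF7 cells (Homo sapiens) for cytotoxicity, read by MTT assay, with a stated time of 96 h; a higher number here means a weaker inhibitor, a lower number a stronger inhibitor. Compound 2 `COc1cc(C(=O)c2cn(-c3ccccc3)cc2-c2cccc([N+](=O)[O-])c2)cc(OC)c1OC` gives 50 nM in this assay; the change is 3-nitrophenyl in place of 2-nitrophenyl on an aromatic carbon and the step is a 1.0-fold higher number from compound 1 to compound 2 (0.01 log units; within the scatter). Compound 3 `COc1cc(C(=O)c2cn(-c3ccc(F)cc3)cc2-c2ccccc2[N+](=O)[O-])cc(OC)c1OC` differs from compound 1 by fluoro in place of hydrogen on an aromatic carbon, a step of a 1.3-fold lower number from compound 1 to compound 3 (0.11 log units; within the scatter). In this assay compound 3 gives 38 nM. Compound 4 `COc1cc(C(=O)c2cn(-c3ccc(F)cc3)cc2-c2cccc([N+](=O)[O-])c2)cc(OC)c1OC` is not yet measured; it differs from compound 3 by 3-nitrophenyl in place of 2-nitrophenyl on an aromatic carbon. This is the same kind of change as from compound 1 to compound 2, not the same: in compound 3 the place lies two ring bonds from the ring atom that bears a 4-fluorophenyl group (7 heavy atoms), whereas in compound 1 that ring atom bears a phenyl group (6 heavy atoms). The expected step from compound 3 to compound 4 in this assay is a 1.1-fold higher number from compound 3 to compound 4 (0.02 log units; within the scatter), resting on the flat earlier step a 1.0-fold higher number from compound 1 to compound 2 (0.01 log units; within the scatter). Compound 4 is therefore estimated at 40 nM, with a range from 20 nM to 80 nM.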

Compound 4, half-maximal inhibitory concentration: 440 nM
Beside the measured number, compound 4's estimate is 11-fold (1.04 log units) below it; the whole stated range lies below it.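

In this assay the change from 2-nitrophenyl to 3-nitrophenyl does not carry from the core of compound 1 to the core of compound 3, where it gives a 12-fold higher number from compound 3 to compound 4 (1.06 log units; beyond the scatter) and departs from the earlier step: the same change on two cores in this assay, a 1.0-fold higher number (0.01 log units; within the scatter) from compound 1 to compound 2 and a 12-fold higher number (1.06 log units; beyond the scatter) from compound 3 to compound 4, 11-fold (1.05 log units) apart, beyond the scatter of two such steps.
Fluoro in place of hydrogen likewise depends on which nitrophenyl group is present, giving an 8.8-fold higher number from compound 2 to compound 4 (0.94 log units; beyond the scatter) and departing from its step with 2-nitrophenyl: the same change on two cores in this assay, a 1.3-fold lower number (0.11 log units; within the scatter) from compound 1 to compound 3 and an 8.8-fold higher number (0.94 log units; beyond the scatter) from compound 2 to compound 4, 11-fold (1.05 log units) apart, beyond the scatter of two such steps.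
These four compounds show that the two changes do not add in this assay, but they do not show why or how far this extends across the series.

Open, on these data alone, is whether chloro or methoxy in place of fluoro gives the same dependence. Also open, as far as these compounds go, is whether an amine or a nitrile in place of the nitro group does so.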